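The source may hold more compounds than are shown below. What is called first, only, known or untested is meant among the compounds shown, and "the series" means these compounds.

Compound 1 `Cc1ccc(C2=NO[C@@H]3[C@H](CO)C[C@H](CO)[C@H]23)cc1` and compound 2 `N#Cc1ccc(C2=NO[C@@H]3[C@H](CO)C[C@H](CO)[C@H]23)cc1` share one core and differ only at one aromatic carbon. In a functional assay on HeLa cells (Homo sapiens) for cytotoxicity, read by MTT assay, with a stated time of 48 h (a lower number here means a stronger inhibitor, a higher number a weaker inhibitor), compound 1 gives 26.5 ug/mL. Compound 2 gives > 50 ug/mL in this assay; that is a limit of the assay, not a number, and it is the limit of > 50 ug/mL in this assay, at which 1 of the 2 values shown sits. Among the measured compounds shown here, the single measured step, an at least 1.8-fold higher number from compound 1 to compound 2 (0.27 log units; that floor lies within the scatter), therefore tells only that the cyano compound is no stronger than the methyl one, and its floor lies within the scatter.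

Compound 3 `OC[C@@H]1C[C@H](CO)[C@@H]2C(c3ccc(F)cc3)=NO[C@H]12` has not been measured. It differs from compound 2 in one place: fluoro in place of cyano on an aromatic carbon. For the measured compounds named here, this takes away the cyano whose arrival made up the measured step, but no measured step shows what fluoro does in its place. The expected step of an at least 1.4-fold lower number from compound 2 to compound 3 (0.15 log units; that floor lies within the scatter) is thus a modest move back toward a readable number, carrying wide uncertainty. Compound 3 is estimated at 35 ug/mL, between 15 ug/mL and 80 ug/mL, and it may again come out only as a limit in this assay.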

Compound 3, half-maximal inhibitory concentration: > 50 ug/mL
Compound 3: only a limit was reported; the forecaster's own chance of this, stated with the estimate: 40%; at least 1.4-fold (0.15 log units) between middle value and limit.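

Compound 3, like compound 2, is reported only as a limit in this assay, so the change from cyano to fluoro cannot be read, neither in direction nor in size. What is new is that a second replacement for methyl on this aromatic carbon, this time a group of a single heavy atom, also gives no readable number, which leaves compound 1 as the only compound shown with a measured value: the limit of > 50 ug/mL in this assay, at which 2 of the 3 values shown sit. The comparison with methyl gives an at least 1.8-fold higher number from compound 1 to compound 3 (0.27 log units; that floor lies within the scatter), so fluoro, like cyano, is no stronger than methyl here, although this floor does not establish a real difference.

From the compounds shown here alone, how far the true values of compound 2 and compound 3 lie past the limit remains unknown, and so does whether either really differs from compound 1. The compounds shown also leave open what an amine, a carboxylic acid or a longer chain on this aromatic carbon would do, and whether any group here would give a lower number than methyl.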